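The compounds below may be only part of what the source reports. "The series", "measured", "known", "first", "only" and "open" are said of these compounds alone.

Within the data shown here, compound 1 `CCc1cccc2c(OC)c(-c3occ(C)c3C(=S)OC)ccc12` is the only member of this small set with a number of its own: in a functional assay on KB cells (Homo sapiens) for cytotoxicity, read by MTT assay, with a stated time of 72 h (a higher number here means that more compound is needed for the effect, a lower number that less compound is needed), compound 1 gives 4.3 ug/mL. Compound 2 `CCc1cccc2c(OC)c(-c3occ(C)c3CBr)ccc12` sits at a limit of this assay rather than at a number, giving > 10 ug/mL. Among the measured compounds shown here, the one measured step, an at least 2.3-fold higher number from compound 1 to compound 2 (0.36 log units; beyond the scatter), therefore has only a lower bound, resting on (the limit of > 10 ug/mL in this assay, at which 1 of the 2 values shown sits). Compound 3 `CCc1cccc2c(OC)c(-c3occ(C)c3COC(C)=O)ccc12` is the next one, and it differs from compound 2 by acetoxy in place of bromo on a saturated chain carbon bound to an aromatic carbon. For the measured compounds named here, no measured step carries this change; the only step known concerns a different replacement on an aromatic carbon, so it bears on compound 3 only in telling that compound 2 lies at the limit from which the new compound starts. With compound 2 known only as a limit, the expectation for compound 3 in this assay is an open one. Compound 3 is expected to give about 10 ug/mL, within a range from 3 ug/mL to 30 ug/mL. The step that this estimate means, a number no higher from compound 2 to compound 3 (the limit leaves the size open), is thus expected to be small against the limit, with a considerable chance that the assay again reports only a limit.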

Compound 3, concentration for half-maximal effect: > 10 ug/mL
Compound 3: only a limit was reported; the forecaster's own chance of this, stated with the estimate: 50%; the middle value sits exactly at the limit.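

In this assay compound 3 gives > 10 ug/mL, which is a limit of the assay and not a number. Acetoxy in place of bromo on a saturated chain carbon bound to an aromatic carbon therefore leaves the series at the same limit, and the step between these two compounds cannot be read; the change shows only that a second, larger group at this place also yields no number of its own. The comparison that can be read is with the group carried by compound 1, where there is an at least 2.3-fold higher number from compound 1 to compound 3 (0.36 log units; beyond the scatter), a lower bound only, so that neither bromomethyl nor acetoxymethyl gives a number in this assay and the picture here rests on a limit: the limit of > 10 ug/mL in this assay, at which 2 of the 3 values shown sit.

As far as these compounds go, how far past the limit compound 2 and compound 3 lie, and whether they differ from each other at all, remains open. Also open, from the compounds shown here alone, is whether a hydroxymethyl or an aminomethyl group at this place would give a measurable number in this assay, or whether only the group of compound 1 does so.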